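Adding Fluorine to a Three-Ring Arm

The source may report more compounds than this note shows. Statements on the series, on what has been measured and on what is new or still open speak of the compounds shown alone.

Compound 1 `Oc1cccc2[nH]c(-c3ccc(-c4ccc(-c5ccccc5)cc4)cc3)nc12` and compound 2 `Oc1cccc2[nH]c(-c3ccc(-c4ccc(-c5ccc(F)cc5)cc4)cc3)nc12` differ in one spot only: fluoro in place of hydrogen on an aromatic carbon. In a functional assay on A549 cells (Homo sapiens) for inhibition, read by sulforhodamine B assay (a lower number here means a stronger inhibitor of growth, a higher number a weaker inhibitor of growth), compound 1 gives 8320 nM and compound 2 gives 170 nM, so this single change made a 49-fold lower number from compound 1 to compound 2 (1.69 log units; beyond the scatter). Compound 3 `Cc1ccc2[nH]c(-c3ccc(-c4ccc(-c5ccccc5)cc4)cc3)nc2c1` has a different core; how the two cores differ is not broken down here. In this assay compound 3 gives 3630 nM. Compound 4 `Cc1ccc2[nH]c(-c3ccc(-c4ccc(-c5ccc(F)cc5)cc4)cc3)nc2c1` carries the same change that turned compound 1 into compound 2: fluoro in place of hydrogen on an aromatic carbon. Because that change earlier gave a 49-fold lower number from compound 1 to compound 2 (1.69 log units; beyond the scatter), a clear drop is expected for compound 4, although with a single earlier example and a different core its size is uncertain. Compound 4 is therefore estimated at 300 nM, with a likely range from 80 nM to 1200 nM. That estimate would mean a step of a 12-fold lower number from compound 3 to compound 4 (1.08 log units; beyond the scatter).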

Compound 4, concentration for 50% growth inhibition: 6030 nM
Estimate against measurement, compound 4: 20-fold (1.30 log units) below; measured number above the stated range.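

In this assay the swap of phenyl to 4-fluorophenyl on the core of compound 3 gave a 1.7-fold higher number from compound 3 to compound 4 (0.22 log units; within the scatter), so here the fluoro brought no change that stands clear of ordinary repeat variation. Set beside the earlier pair, the same change did not carry over from one core to the other: the same change on two cores in this assay, a 49-fold lower number (1.69 log units; beyond the scatter) from compound 1 to compound 2 and a 1.7-fold higher number (0.22 log units; within the scatter) from compound 3 to compound 4, 81-fold (1.91 log units) apart, beyond the scatter of two such steps. This shows that, in these two pairs, the effect of the fluoro cannot be read from one core to the other, but it does not show which feature of the cores accounts for the gap.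

On these data alone, it remains open whether a chloro or a methoxy group in the same place would behave differently on the two cores. As far as these compounds go, how the fluoro would act on a third core is also open.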